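This account rests on a few compounds, and the source may have more. Where it says the series, first, only, none or still open, it means among the compounds named here.

Compound 1 `c1ccc(-c2nc3ccccn3c2NCC2CC2)nc1` gives 19400 nM in an ADME assay on THP-1 cells (Homo sapiens) for cytotoxicity; on this read-out higher numbers stand for lower toxicity in this test and lower numbers for higher toxicity in this test. Compound 2 `FC(F)(F)Oc1ccc(Nc2c(-c3ccccn3)nc3ccccn23)cc1` gives > 50000 nM in this assay, which is a limit of the assay and not a number.

Among the measured compounds shown here, compound 1 thus holds the only number in this assay; the other value sits at the limit (the limit of > 50000 nM in this assay, at which 1 of the 2 values shown sits). Compound 3 `COc1ccccc1Nc1c(-c2ccccn2)nc2ccccn12` differs from compound 1 by 2-methoxyphenyl in place of cyclopropylmethyl on a nitrogen on an aromatic ring. For the measured compounds named here, no measured step of this kind exists in the set. For compound 3 the step of a 1.5-fold higher number from compound 1 to compound 3 (0.19 log units; within the scatter) is expected to be small and upward, close to the scatter. Compound 3 is estimated at 30000 nM, within 10000 nM to 60000 nM.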

Compound 3, half-maximal cytotoxic concentration: > 50000 nM
Compound 3: only a limit was reported; the forecaster's own chance of this, stated with the estimate: 35%; at least 1.6-fold (0.22 log units) between middle value and limit.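

In this assay, among the compounds shown here, 2-methoxyphenyl in place of cyclopropylmethyl on a nitrogen on an aromatic ring gives the first step at this position: an at least 2.5-fold higher number from compound 1 to compound 3 (0.41 log units; beyond the scatter). Compound 3 carries a limit of the assay and not a number, so this step has a floor but no known full size: the limit of > 50000 nM in this assay, at which 2 of the 3 values shown sit.

Open, going by these compounds, is whether the step follows the six-membered aromatic ring itself or its methoxy group, which an unsubstituted phenyl on this nitrogen would separate. Also open, on these data alone, is how a longer alkyl chain or an amine-bearing chain there reads in this assay.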